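Thiazolidinone series, quinolinone core: paw edema inhibition notes

The compounds below may be only part of what the source reports. "The series", "measured", "known", "first", "only" and "open" are said of these compounds alone.

Measured so far, in a functional assay on the whole organism (strain albino) for inhibition, with Rattus norvegicus as the target, read by paw edema, with stated times of 1 h and 3 h, at a dose of 100 mg/kg by the oral route; a lower number here means less inhibition, a higher number more inhibition at the dose given (going by the name of the read-out):
compound 1 `COc1ccc(C2SCC(=O)N2c2ccc3c(C)cc(=O)[nH]c3c2)cc1`, 21.4%
compound 2 `Cc1cc(=O)[nH]c2cc(N3C(=O)CSC3c3ccccc3[N+](=O)[O-])ccc12`, 24.1%
compound 3 `Cc1cc(=O)[nH]c2cc(N3C(=O)CSC3c3ccc(N(C)C)cc3)ccc12`, 13.3%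

Compound 3 gives the lowest number of the three; its nearest neighbour is compound 1, a gap within the scatter, and only the gap to compound 2 is beyond it, as a number 10.8 percentage points lower from compound 2 to compound 3 (beyond the scatter) shows. Compound 4 `Cc1cc(=O)[nH]c2cc(N3C(=O)CSC3/C=C/c3ccccc3)ccc12` differs from compound 3 at the saturated ring carbon: 2-phenylethenyl in place of 4-(dimethylamino)phenyl on a saturated ring carbon.

Two measured steps change the group on that same carbon. a number 2.7 percentage points higher from compound 1 to compound 2 (within the scatter) is within the scatter; a number 10.8 percentage points lower from compound 2 to compound 3 (beyond the scatter) is modest. Replacements there have thus moved this assay only slightly, and none of them introduced a 2-phenylethenyl, so no direction can be read from them. Compound 4 is expected to sit near compound 3, with a number 4.7 percentage points higher from compound 3 to compound 4 (within the scatter) not beyond the scatter. The estimate for compound 4 is 18%, between 7% and 30%.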

Compound 4, a percentage reported as inhibition, in the whole organism at one dose (the size of the read-out at that dose, not a potency): 20.8%
The estimate for compound 4 lay 2.8 percentage points below the measured number, within the range that was stated.
By their numbers in this assay, from the lowest: compounds 3, 4, 1 and 2 (each within the scatter of the next, the first and the last beyond it).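

In this assay the 2-phenylethenyl, with its double bond outside aromatic rings, stays within the scatter of all three phenyl groups on the saturated ring carbon (a number 7.5 percentage points higher from compound 3 to compound 4 (within the scatter); a number 3.3 percentage points lower from compound 2 to compound 4 (within the scatter); a number 0.6 percentage points lower from compound 1 to compound 4 (within the scatter)). This carbon therefore carries a group other than a substituted phenyl without a step beyond the scatter, and the only such gap remains that between compound 2 and compound 3. No measurement here explains these numbers. Going by these compounds, whether a 2-phenylethyl, a carboxylic acid or an amine on this carbon would move the number beyond the scatter remains open.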